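Chain extension at the amide nitrogen of compound 3

A few compounds are considered here, and "the series" means these few. Any claim that something is new, unique, unknown or untested is made for them only; others in the source may bear on it.

Compound 1, `CC(C)(C)OC(=O)NCCCCNC(=O)CN1CN(c2ccccc2)C2(CCN(C(=O)c3ccc(C(C)(C)C)cc3)CC2)C1=O`: "not determined" (no result reported).
Compound 2, `CC(C)(C)OC(=O)NCCNC(=O)CN1CN(c2ccccc2)C2(CCN(C(=O)c3ccc(C(C)(C)C)cc3)CC2)C1=O`: 10900 nM.
Compound 3, `CC(C)(C)c1ccc(C(=O)N2CCC3(CC2)C(=O)N(CC(=O)NCN)CN3c2ccccc2)cc1`: 26500 nM.

In an assay on HEK293 cells for displacement of a labelled ligand from NPC1-like intracellular cholesterol transporter 1 (Homo sapiens) (on this read-out lower numbers stand for stronger inhibition and higher numbers for weaker inhibition), compound 3 stands highest of the two numbers, compound 2 being the nearest with the step of a 2.4-fold higher number from compound 2 to compound 3 (0.39 log units; beyond the scatter); compound 1 contributes no number. Compound 4, `CC(C)(C)c1ccc(C(=O)N2CCC3(CC2)C(=O)N(CC(=O)NCCN)CN3c2ccccc2)cc1`, differs from compound 3 by aminomethyl in place of amino on a saturated chain carbon bound to an amide-type nitrogen. Among the compounds with values here, the only measured step at this position is a 2.4-fold higher number from compound 2 to compound 3 (0.39 log units; beyond the scatter), modest and beyond the scatter, and it ran alongside removal of the tert-butoxycarbonyl group, so it bears on the present change only loosely. For compound 4 a modest step toward a lower number in this assay, or none beyond the scatter, is expected. Compound 4 is therefore estimated at 18000 nM, with a range of 7000 nM to 45000 nM, meaning an expected step of a 1.5-fold lower number from compound 3 to compound 4 (0.17 log units; within the scatter).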

Compound 4, half-maximal inhibitory concentration: 7000 nM
Compound 4: middle estimate off by 2.6-fold (0.41 log units), on the high side; the range from low to high includes it.
By their numbers in this assay, from the lowest: compounds 4 and 2 (each within the scatter of the next); then compound 3.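

Within this assay aminomethyl in place of amino on a saturated chain carbon bound to an amide-type nitrogen gives a 3.8-fold lower number from compound 3 to compound 4 (0.58 log units; beyond the scatter) and so shows that this position responds to chain length alone, with no tert-butoxycarbonyl change involved. Hydrogen in place of tert-butoxycarbonyl on an amine nitrogen gives a 1.6-fold lower number from compound 2 to compound 4 (0.19 log units; within the scatter) and so shows no difference beyond the scatter on the 2-aminoethyl chain.

Nothing at hand explains the chain-length step. On these data alone, whether a 4-aminobutyl chain, or a carboxylic acid in place of the terminal amine, would lower the number further remains open.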